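This account rests on a few compounds, and the source may have more. Where it says the series, first, only, none or still open, it means among the compounds named here.

Working notes on the series. In a functional assay on A549 cells (Homo sapiens) for cytotoxicity, read by resazurin assay, with a stated time of 72 h (a lower number here means a stronger inhibitor, a higher number a weaker inhibitor), compound 1 `O=C(/C=C/c1ccc(OCCCCCO[N+](=O)[O-])c(O)c1)OCCCCCO[N+](=O)[O-]` gives 450 nM, while compound 2 `O=C(/C=C/c1ccc(O)c(O)c1)OCc1c(-c2ccccc2)no[n+]1[O-]` gives 2710 nM. Compound 2 therefore holds the higher of the two numbers and is the weaker inhibitor of the pair, with a gap beyond the usual scatter. Compound 3 `COc1cc(/C=C/C(=O)OCc2c(-c3ccccc3)no[n+]2[O-])ccc1O` has not yet been measured in this assay. It departs from compound 2 in one place: methyl in place of hydrogen on an oxygen on an aromatic ring. In words, this is methyl in place of hydrogen on an oxygen on an aromatic ring, which turns the 3,4-dihydroxyphenyl into a 4-hydroxy-3-methoxyphenyl. Among the compounds with values here, no measured pair isolates this change, and compound 1 differs from compound 2 in more than one place, so the data offer no direct guide to its size. Within the data shown here, only a small move toward a weaker inhibitor is expected, with no step clearly beyond the scatter. The estimated change is a 1.4-fold higher number from compound 2 to compound 3 (0.15 log units; within the scatter). For compound 3 the expected value is 3800 nM, within an estimated range of 1500 nM to 10000 nM.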

Compound 3, half-maximal inhibitory concentration: 2060 nM
Compound 3: middle estimate off by 1.8-fold (0.27 log units), on the high side, within the range that was stated.
By their numbers in this assay, from the lowest: compound 1; then compounds 3 and 2 (each within the scatter of the next).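

In this assay, within the data shown here, methyl in place of hydrogen on an oxygen on an aromatic ring gives a 1.3-fold lower number from compound 2 to compound 3 (0.12 log units; within the scatter) and this is the first step that isolates a single change. Hydroxy to methoxy, here 3,4-dihydroxyphenyl to 4-hydroxy-3-methoxyphenyl, therefore leaves the cytotoxicity read-out indistinguishable from that of the parent, and a free hydroxy at this place is not required to hold the number at this level on the core of compound 2. No accompanying measurement bears on this result, so the step stands as an observation without an explanation.

Still open, going by these compounds, is whether this position stays as insensitive to a larger or different group, such as a longer chain on the same oxygen, a benzyl ether, or an amine in place of the oxygen, and whether methyl on the other hydroxy of the ring would behave in the same way. Compound 1 differs from compound 2 and compound 3 in more than one place, so the compounds shown do not reveal which of its differences accounts for its separate standing.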